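Methyl in Place of Chloro in a Level Series

This account rests on a few compounds, and the source may have more. Where it says the series, first, only, none or still open, it means among the compounds named here.

In a functional assay, read by chemiluminescence (on this read-out higher numbers stand for weaker inhibition and lower numbers for stronger inhibition), compound 1 (`O=C(/C=C/c1ccc(Cl)cc1)c1ccccc1O`) gives 713000 nM and compound 2 (`COc1ccccc1/C=C/C(=O)c1ccccc1O`) gives 599000 nM while compound 3 (`COc1cc(O)c(C(=O)/C=C/c2ccc(Cl)cc2)c(OC)c1`) gives 657000 nM on the same read-out. Compound 3 thus stands level with both others, its number lying within the scatter of each. Compound 4 (`COc1cc(O)c(C(=O)/C=C/c2ccc(C)cc2)c(OC)c1`) has methyl in place of chloro on an aromatic carbon, para to a large group (methyl in place of chloro on an aromatic carbon). Going by the values given here, no measured pair shows this change on its own, so the three level values are the only guide. The estimated step (a 1.0-fold lower number from compound 3 to compound 4 (0.00 log units; within the scatter)) is expected to stay within the scatter in this assay and to have no clear direction. For compound 4 the expected value is 650000 nM with an estimated range from 320000 nM to 1200000 nM in this measurement.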

Compound 4, half-maximal inhibitory concentration: 665000 nM
Compound 4: middle estimate off by 1.0-fold (0.01 log units), on the low side, and the stated range covers the measured number.
By their numbers in this assay, from the lowest: compounds 2, 3, 4 and 1 (each within the scatter of the next).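

In this assay, going by these compounds alone, exchanging 4-chlorophenyl for 4-methylphenyl gives a 1.0-fold higher number from compound 3 to compound 4 (0.01 log units; within the scatter), the first direct reading of this change, and at this place on the shared core the two groups cannot be told apart. The earlier compounds shown here offered no pair with this single difference. Nothing at hand explains this level result. From the compounds shown here alone, whether the number would stay level with an amine or a carboxylic acid at this place remains open, as does whether any other group there would move it beyond the scatter.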